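A larger carboxy side chain on compound 3

A few compounds are considered here, and "the series" means these few. Any claim that something is new, unique, unknown or untested is made for them only; others in the source may bear on it.

Values in a functional assay on BXPC-3 cells (Homo sapiens) for antiproliferative activity, read by MTT assay, with a stated time of 24 h (a higher number here means a weaker inhibitor, a lower number a stronger inhibitor), so far
Compound 1 `CCn1c(C(=O)NCC(=O)OC)ccc1C(CC)(CC)c1ccc(OCS(=O)(=O)c2ccccc2)c(C)c1` gives 20000 nM as a measured number
Compound 2 `CCn1c(C(=O)N[C@@H](CO)CCO)ccc1C(CC)(CC)c1ccc(OCS(=O)(=O)c2ccccc2)c(C)c1` gives > 50000 nM as a limit of the assay, not a number
Compound 3 `CCn1c(C(=O)N[C@H](C)C(=O)O)ccc1C(CC)(CC)c1ccc(OCS(=O)(=O)c2ccccc2)c(C)c1` gives 20100 nM as a measured number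

In this assay, for the measured compounds named here, compound 3 stands at 20100 nM on the numbers so far. Going by the values given here, the only comparison between two real numbers is a 1.0-fold higher number from compound 1 to compound 3 (0.00 log units; within the scatter) on swapping the group on the amide-type nitrogen, so those two compounds sit level. Going by these compounds, the steps of an at least 2.5-fold higher number from compound 1 to compound 2 (0.39 log units; beyond the scatter) and an at least 2.4-fold lower number from compound 2 to compound 3 (0.39 log units; beyond the scatter) rest on a limit, so their true size stays open.

Compound 4 `CCn1c(C(=O)N[C@H](C(=O)O)C(C)C)ccc1C(CC)(CC)c1ccc(OCS(=O)(=O)c2ccccc2)c(C)c1` is still unmeasured. Its change (1-carboxy-2-methylpropyl in place of 1-carboxyethyl on an amide-type nitrogen) puts 1-carboxy-2-methylpropyl in place of 1-carboxyethyl on an amide-type nitrogen. Among the compounds with values here, no measured pair tests this exact swap. Compound 4 keeps the carboxy group of compound 3 (20100 nM) and gains only a longer branch, so little movement is expected. The expected step is a 1.0-fold lower number from compound 3 to compound 4 (0.00 log units; within the scatter) in this assay and would lie within the scatter. The estimate for compound 4 is 20000 nM with a range from 8000 nM to 50000 nM as the expected span.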

Compound 4, half-maximal inhibitory concentration: 16200 nM
Estimate against measurement, compound 4: 1.2-fold (0.09 log units) above; low and high end bracket the measured number.
By their numbers in this assay, from the lowest: compounds 4, 1 and 3 (each within the scatter of the next). At a limit, above all of these: compound 2.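

In this assay, going from 1-carboxyethyl to the larger 1-carboxy-2-methylpropyl on the amide-type nitrogen leaves the reading level, with a 1.2-fold lower number from compound 3 to compound 4 (0.09 log units; within the scatter). The (methoxycarbonyl)methyl group of compound 1 also sits level with the new side chain, with a 1.2-fold lower number from compound 1 to compound 4 (0.09 log units; within the scatter), so compounds 1, 3 and 4 show that this position accepts all three groups without a step beyond the scatter, and compound 2 goes against that pattern. Compound 2 is held only at a limit of the assay, so an at least 3.0-fold lower number from compound 2 to compound 4 (0.48 log units; beyond the scatter) gives a lower bound and its true size stays open: the limit of > 50000 nM in this assay, at which 1 of the 4 values shown sits.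

Going by these compounds, whether a side chain ending in an amine, or a benzyl group or a much longer carbon chain, would move the number remains open. The compounds shown also leave open what the mirror-image form of the 1-carboxy-2-methylpropyl group would give.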